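The source may hold more compounds than are shown below. What is called first, only, known or untested is meant among the compounds shown, and "the series" means these compounds.

Compounds measured in a functional assay on NCI-H460 cells (Homo sapiens) for cytotoxicity, read by sulforhodamine B assay; a higher number here means a weaker inhibitor of growth, a lower number a stronger inhibitor of growth (each value is a limit of the assay):
- Compound 1 `CC1=CC[C@@H]([C@@](C)(O)CCCC(C)(C)NC(=S)N/N=C\c2ccc(C)cc2)CC1` gives > 100000 nM
- Compound 2 `COc1ccc(/C=N\NC(=S)NC(C)(C)CCC[C@](C)(O)[C@@H]2CC=C(C)CC2)cc1` gives > 100000 nM
- Compound 3 `CC1=CC[C@@H]([C@@](C)(O)CCCC(C)(C)NC(=S)N/N=C\c2ccccc2Cl)CC1` gives > 100000 nM

Compound 3 stands at > 100000 nM, which is a limit and not a number. What the series shows so far is the limit of > 100000 nM in this assay, at which 3 of the 3 values shown sit. The next compound is compound 4 `CC1=CC[C@@H]([C@@](C)(O)CCCC(C)(C)NC(=S)N/N=C\c2cccc(Cl)c2)CC1`, in which 3-chlorophenyl takes the place of 2-chlorophenyl on a carbon with a double bond to nitrogen (3-chlorophenyl in place of 2-chlorophenyl on a carbon with a double bond to nitrogen). The measured steps that bear on this change are a step that the two limits leave unreadable from compound 1 to compound 3 and a step that the two limits leave unreadable from compound 2 to compound 3, and alongside them stands a step that the two limits leave unreadable from compound 1 to compound 2. None of them offers a size to carry over. In this assay no step beyond the scatter is expected in either direction, and this expectation rests on compound 3 at > 100000 nM, itself a limit. The expected change is a number no higher from compound 3 to compound 4 (the limit leaves the size open). For compound 4 the estimate is 100000 nM, with an expected range from 50000 nM to 200000 nM.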

Compound 4, concentration for total growth inhibition: > 100000 nM
Compound 4 gave a limit, no number; the forecaster's own chance of this, stated with the estimate: 85%; the middle value lies on the limit itself.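

Compound 4 gives > 100000 nM, which is a limit and not a number. Its steps from compound 1, compound 2 and compound 3 therefore cannot be read: the limit of > 100000 nM in this assay, at which 4 of the 4 values shown sit.

The compounds shown leave open whether 3-chlorophenyl and 2-chlorophenyl differ in their effect on growth, and how strongly any of these compounds inhibits it.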